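Working notes: methyl for chloro, compound 1 to compound 4

This account rests on a few compounds, and the source may have more. Where it says the series, first, only, none or still open, it means among the compounds named here.

Measured so far:
compound 1 `Cc1cc(=O)[nH]c2cc(NC(=O)c3ccccc3Cl)ccc12` — 1.55
compound 2 `Cc1cc(=O)[nH]c2cc(NC(=O)c3ccc(Cl)cc3Cl)ccc12` — 1.83
compound 3 `Cc1cc(=O)[nH]c2cc(NC(=O)c3c(Br)cccc3Br)ccc12` — 1.75

In a physicochemical assay for lipophilicity (on this read-out higher numbers stand for higher lipophilicity and lower numbers for lower lipophilicity), compound 1 gives 1.55, the lowest of the three numbers, although both compound 3 and compound 2 sit within the scatter of it, so no order among the three is claimed. Compound 4 `Cc1ccccc1C(=O)Nc1ccc2c(C)cc(=O)[nH]c2c1` differs from compound 1 by methyl in place of chloro on an aromatic carbon, that is, 2-chlorophenyl becomes 2-methylphenyl. Among the compounds with values here, one measured step bears on it: a number 0.28 log units higher from compound 1 to compound 2 (within the scatter). That step adds a chloro rather than exchanging one, so it is only an indirect guide, and it was itself within the scatter. The exchange is therefore expected to move the read-out little, if at all: a number 0.10 log units lower from compound 1 to compound 4 (within the scatter) is the estimated step. Compound 4 is estimated at 1.45, with a range from 1.15 to 1.75.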

Compound 4, partition coefficient: 1.71
Beside the measured number, compound 4's estimate is 0.26 log units below it, and the stated range covers the measured number.
By their numbers in this assay, from the lowest: compounds 1, 4, 3 and 2 (each within the scatter of the next).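

At this position, on an aromatic carbon ortho to a large group, this assay gives a number 0.16 log units higher from compound 1 to compound 4 (within the scatter) for methyl in place of chloro. The earlier step added a chloro, whereas this one exchanges the group at the position itself, and the read-out does not tell the two groups apart. No supporting measurement speaks to this result.

As far as these compounds go, whether an amine or a carboxylic acid here would give a step beyond the scatter stays open. From the compounds shown here alone, whether the exchange reads alike with a second group on the ring also stays open.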